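Replacing the Fluorophenyl Ring with a Dimethoxyphenyl Ring

This account rests on a few compounds, and the source may have more. Where it says the series, first, only, none or still open, it means among the compounds named here.

For the measured compounds named here, compound 1 `O=C1C(=Cc2ccc(F)cc2)C(=O)N(c2ccc(Cl)cc2)N1c1ccc(Cl)cc1` was tested in a functional assay on SMMC-7721 cells (Homo sapiens) for cytotoxicity, read by MTT assay, with a stated time of 72 h (a higher number here means a weaker inhibitor, a lower number a stronger inhibitor), where compound 1 gives 23300 nM, the higher of the two numbers known, though compound 2 sits within the scatter of it. Compound 2 `O=C1C(=Cc2cccc(Cl)c2)C(=O)N(c2ccc(Cl)cc2)N1c1ccc(Cl)cc1` gives 20200 nM in this assay. Going by the values given here, the only step measured, a 1.2-fold lower number from compound 1 to compound 2 (0.06 log units; within the scatter), changed the same ring as the one now in question. Compound 3 `COc1ccc(C=C2C(=O)N(c3ccc(Cl)cc3)N(c3ccc(Cl)cc3)C2=O)cc1OC` differs from compound 1 by 3,4-dimethoxyphenyl in place of 4-fluorophenyl on a double-bonded chain carbon bound to a double-bonded ring carbon. Because that one step of a 1.2-fold lower number from compound 1 to compound 2 (0.06 log units; within the scatter) stayed within the scatter, the expected step of a 1.1-fold lower number from compound 1 to compound 3 (0.05 log units; within the scatter) is none beyond the scatter. Compound 3 is therefore estimated at 21000 nM, with a range from 8000 nM to 55000 nM.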

Compound 3, half-maximal inhibitory concentration: > 128000 nM
Compound 3: only a limit was reported; the forecaster's own chance of this, stated with the estimate: 10%; middle value at least 6.0-fold (0.78 log units) from the limit.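

The ring on the double-bonded chain carbon is not free to change in this assay: 3,4-dimethoxyphenyl gives an at least 5.4-fold higher number from compound 1 to compound 3 (0.73 log units; beyond the scatter) and an at least 6.3-fold higher number from compound 2 to compound 3 (0.80 log units; beyond the scatter), although the earlier swap between the fluorophenyl and chlorophenyl rings stayed within the scatter. The result for compound 3 is only a limit: the limit of > 128000 nM in this assay, at which 1 of the 3 values shown sits.

Going by these compounds, whether both methoxy groups are needed for this change, or one alone would give the same result, remains open. So does how a ring carrying a hydroxyl group or an amine would behave at this position.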